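Aryl acetamide piperidine series: methyl removal on the anilide

This account rests on a few compounds, and the source may have more. Where it says the series, first, only, none or still open, it means among the compounds named here.

Measured so far:
- compound 1 `Cc1cc(NC(=O)CN2CCC(c3cccc[n+]3[O-])CC2)ccc1F`: 18 nM
- compound 2 `COc1cccc(C)c1NC(=O)CN1CCC(c2cccc[n+]2[O-])CC1`: 340 nM
- compound 3 `Oc1ccc(N2CCN(Cc3nc4ccccc4[nH]3)CC2)nc1`: 2.4 nM

In a functional assay on HEK293 cells for agonist activity at D(4) dopamine receptor (Homo sapiens), read by FLIPR (a lower number here means that less compound is needed, a higher number that more compound is needed for the effect), compound 1 stands second highest of the three numbers; compound 3 gives the lowest number of the set, while compound 2 gives the highest, both gaps lying beyond the scatter. Compound 4 `O=C(CN1CCC(c2cccc[n+]2[O-])CC1)Nc1ccc(F)cc1` differs from compound 1 by hydrogen in place of methyl on an aromatic carbon — hydrogen in place of methyl on an aromatic carbon, ortho to the fluoro group and meta to the large group. Within the data shown here, no directly comparable pair has been measured for this change. The expectation for the step from compound 1 to compound 4 is a modest rise in the number, a 2.8-fold higher number from compound 1 to compound 4 (0.44 log units; beyond the scatter), of a size that may or may not exceed the scatter. Compound 4 is thus estimated at 50 nM, with a range from 15 nM to 180 nM.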

Compound 4, half-maximal effective concentration: 85 nM
Compound 4: the middle estimate sits 1.7-fold (0.23 log units) below what was measured; the range from low to high includes it.
By their numbers in this assay, from the lowest: compound 3; then compound 1; then compound 4; then compound 2.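

In this assay, among these compounds, the change from 4-fluoro-3-methylphenyl to 4-fluorophenyl gives a 4.7-fold higher number from compound 1 to compound 4 (0.67 log units; beyond the scatter) and is the first step that differs in one place only. At this aromatic carbon, ortho to the fluoro group and meta to the large group, methyl and hydrogen are therefore not interchangeable. No measurement in hand accounts for this step.

Open, from the compounds shown here alone, is whether an ethyl group or a chlorine atom on this carbon would match methyl or hydrogen. Also open, going by these compounds, is whether removing methyl carries the same cost on the anilide of compound 2.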